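The compounds below may be only part of what the source reports. "The series", "measured", "known", "first", "only" and "open" are said of these compounds alone.

Compound 3 `COc1ccc(-c2cc3ccccc3nc2/C=C/C(=O)c2ccc([N+](=O)[O-])cc2)cc1` sits second highest of the three numbers in a functional assay on MDA-MB-231 cells (Homo sapiens) for antiproliferative activity, read by XTT assay, with a stated time of 72 h; on this read-out higher numbers stand for weaker inhibition and lower numbers for stronger inhibition: compound 3 gives 840 nM, its nearest neighbour being compound 1 `COc1ccc(-c2cc3ccccc3nc2/C=C/C(=O)c2ccc(F)cc2)cc1`, which gives 830 nM, and its furthest being compound 2 `COc1ccc(-c2cc3ccccc3nc2/C=C/C(=O)c2ccc(O)cc2)cc1`, which gives 6350 nM. The step of a 1.0-fold higher number from compound 1 to compound 3 (0.01 log units; within the scatter) lies within the scatter, whereas a 7.7-fold higher number from compound 1 to compound 2 (0.88 log units; beyond the scatter) and a 7.6-fold lower number from compound 2 to compound 3 (0.88 log units; beyond the scatter) are both modest and beyond it. Compound 4 `COc1ccc(-c2cc3ccccc3nc2/C=C/C(=O)c2ccsc2)cc1` differs from compound 3 in one place: thiophen-3-yl in place of 4-nitrophenyl on a carbonyl carbon. Within the data shown here, no measured step swaps the whole aryl ring on the carbonyl carbon; the measured steps only exchange a single substituent on that ring, and the one that adds a hydrogen-bond donor is the one that raises the number. Since thiophen-3-yl brings no donor, compound 4 is expected to stay near compound 3 and compound 1, with the step of a 1.8-fold higher number from compound 3 to compound 4 (0.25 log units; within the scatter) estimated to fall within or only just beyond the scatter. Compound 4 is therefore estimated at 1500 nM, within a range from 500 nM to 5000 nM.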

Compound 4, half-maximal inhibitory concentration: 1060 nM
Compound 4: middle estimate off by 1.4-fold (0.15 log units), on the high side; low and high end bracket the measured number.
By their numbers in this assay, from the lowest: compounds 1, 3 and 4 (each within the scatter of the next); then compound 2.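

In this assay, exchanging the whole aryl ring on the carbonyl carbon, and not just one substituent on it, leaves the number within the scatter: the result is a 1.3-fold higher number from compound 3 to compound 4 (0.10 log units; within the scatter) and a 1.3-fold higher number from compound 1 to compound 4 (0.11 log units; within the scatter). Among these compounds, then, a six-membered aromatic ring of carbon only is not needed at this position, and thiophen-3-yl, a five-membered aromatic ring with 1 hetero atom, serves as well as 4-nitrophenyl or 4-fluorophenyl, while compound 2 alone stands apart, with a 6.0-fold lower number from compound 2 to compound 4 (0.78 log units; beyond the scatter). Nothing available gives a reason for these numbers. The compounds shown leave open whether an amine or a carboxylic acid on the ring would track compound 2 or the other three. They also leave open whether a furan or cyclohexyl ring on the carbonyl carbon would match thiophen-3-yl.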